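Naphthyl attachment point in a pyrazoline series

A few compounds are considered here, and "the series" means these few. Any claim that something is new, unique, unknown or untested is made for them only; others in the source may bear on it.

Two members of the shared core carry measured values. Compound 1 `COc1ccc(C2=NN(C3=NC(c4ccccc4)CS3)C(c3ccc4ccccc4c3)C2)cc1` bears a 4-methoxyphenyl group together with a naphthalen-2-yl group; in a functional assay on HepG2 cells (Homo sapiens) for inhibition, read by CCK-8 assay, with a stated time of 48 h (on this read-out lower numbers stand for stronger inhibition and higher numbers for weaker inhibition), compound 1 gives 12600 nM. Compound 2 `Clc1ccc(C2=NN(C3=NC(c4ccccc4)CS3)C(c3cccc4ccccc34)C2)cc1` bears a 4-chlorophenyl group together with a naphthalen-1-yl group; in this assay compound 2 gives 18700 nM. Compound 2 thus sits at the upper end of the two numbers shown, yet its gap to compound 1 lies within the scatter, so no order between the two can be claimed. Compound 1 and compound 2 differ in two places at once. Among the compounds with values here, no single-change step is available between them.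

Compound 3 `Clc1ccc(C2=NN(C3=NC(c4ccccc4)CS3)C(c3ccc4ccccc4c3)C2)cc1` is the next candidate. It differs from compound 2 only in that (naphthalen-2-yl in place of naphthalen-1-yl on a saturated ring carbon), so the two have the same atoms joined differently. Within the data shown here, with no measured single-change step to lean on, and with compound 1 showing that the naphthalen-2-yl arrangement sits in the same region at 12600 nM, the step from compound 2 to compound 3 is expected to stay within the scatter, in no firm direction, so that a 1.2-fold lower number from compound 2 to compound 3 (0.10 log units; within the scatter) is the expectation. Compound 3 is therefore estimated in this assay at 15000 nM, with a range from 6000 nM to 38000 nM.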

Compound 3, half-maximal inhibitory concentration: 22100 nM
Estimate against measurement, compound 3: 1.5-fold (0.17 log units) below; the measured number falls inside the stated range.
By their numbers in this assay, from the lowest: compounds 1, 2 and 3 (each within the scatter of the next).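

In this assay, naphthalen-2-yl in place of naphthalen-1-yl on a saturated ring carbon gives a 1.2-fold higher number from compound 2 to compound 3 (0.07 log units; within the scatter), so with the 4-chlorophenyl group held fixed, the attachment point of the naphthyl group does not separate the two compounds. The new compound also supplies a single-change step at the other varied place: chloro in place of methoxy on an aromatic carbon, with naphthalen-2-yl held fixed, gives a 1.8-fold higher number from compound 1 to compound 3 (0.24 log units; within the scatter), so neither single change shown moves the number beyond the scatter. No measured information bears on the size of either step.

As far as these compounds go, whether the naphthyl attachment point stays as silent with a 4-methoxyphenyl group in place of the 4-chlorophenyl group remains open. Also open, from the compounds shown here alone, is whether a group of a different kind on that aromatic carbon, such as an amine or a carboxylic acid in place of chloro or methoxy, would give a step beyond the scatter in this assay.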